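This account rests on a few compounds, and the source may have more. Where it says the series, first, only, none or still open, it means among the compounds named here.

Working notes on the series. Within the two numbers available, compound 2 `COc1cc2oc(-c3cccc(C(=O)Nc4ccc(C)cc4)c3)cc(=O)c2c(OC)c1OC` stands lowest in a functional assay on OVCAR-8 cells (Homo sapiens) for inhibition, read by sulforhodamine B assay, tested at 10 uM (on this read-out higher numbers stand for more inhibition at the one concentration tested (going by the name of the read-out) and lower numbers for less inhibition), with 51.8%; its only neighbour, compound 1 `COc1cc2oc(-c3cccc(NC(=O)c4ccc(Br)cc4)c3)cc(=O)c2c(OC)c1OC`, gives 52.9%, and the step of a number 1.1 percentage points lower from compound 1 to compound 2 (within the scatter) lies within the scatter, so the two are not ordered against each other.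

The next member is compound 3 `COc1cc2oc(-c3cccc(C(=O)Nc4ccc(Cl)cc4)c3)cc(=O)c2c(OC)c1OC`. The change from compound 2 is chloro in place of methyl on an aromatic carbon. For the measured compounds named here, the only measured step, a number 1.1 percentage points lower from compound 1 to compound 2 (within the scatter), concerns the direction of the amide and the group at the far end of it, not a chloro in place of methyl on the ring of compound 2, so it does not bear on this change directly. What it does show is that altering the distal aryl group left the read-out essentially unchanged. Going by the values given here, with no measured step touching this exact substitution, the expectation for compound 3 in this assay is no step beyond the scatter, in either direction.

Compound 3 is therefore estimated at 52%, with a range of 36% to 68%. The step that this estimate implies is expected to be a number 0.2 percentage points higher from compound 2 to compound 3 (within the scatter), sitting within the scatter.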

Compound 3, a percentage reported as inhibition, at one concentration (the size of the read-out at that concentration, not a potency): 56.9%
Compound 3: the middle estimate sits 4.9 percentage points below what was measured, within the range that was stated.
By their numbers in this assay, from the lowest: compounds 2, 1 and 3 (each within the scatter of the next).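

In this assay, chloro in place of methyl on an aromatic carbon, para to a large group, gives a number 5.1 percentage points higher from compound 2 to compound 3 (within the scatter), so this exchange of one heavy atom does not separate the two compounds. The step of a number 4 percentage points higher from compound 1 to compound 3 (within the scatter) also lies within the scatter, so the (4-chlorophenyl)carbamoyl group and the ((4-bromophenyl)carbonyl)amino group are not ordered against each other, and the three compounds shown form one unresolved group on this read-out at the single concentration tested. Nothing at hand offers an explanation for these small steps.

From the compounds shown here alone, it remains open whether a more different group at this same position, such as an amine, a carboxylic acid or a longer chain in place of chloro or methyl, would give a step beyond the scatter. Also open is how the chloro and methyl exchange reads with the amide in the direction it has in compound 1, since the compounds shown hold that direction only with the 4-bromophenyl group.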